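Trimming the Piperidinylmethyl Arm From Compound 2

A few compounds are considered here, and "the series" means these few. Any claim that something is new, unique, unknown or untested is made for them only; others in the source may bear on it.

Compound 2 `COC(=O)c1cccc(-c2cnc(C(=O)CCc3ccc(-c4ccc(CN5CCCCC5)cc4)cc3)o2)n1` stands at the higher of the two numbers available. In an assay for inhibition of Fatty-acid amide hydrolase 1 (Rattus norvegicus) (a higher number here means a weaker inhibitor, a lower number a stronger inhibitor), compound 2 gives 9 nM, whereas compound 1 `CS(=O)(=O)c1cnc(C(=O)CCc2ccc(-c3ccccc3)cc2)o1` gives 1.2 nM, a gap beyond the scatter. Compounds 1 and 2 differ in more than one place, so nothing beyond their two numbers can be read from that pair. Compound 3 `COC(=O)c1cccc(-c2cnc(C(=O)CCc3ccc(-c4ccccc4)cc3)o2)n1` is compound 2 with a single change: hydrogen in place of (piperidin-1-yl)methyl on an aromatic carbon. Compound 1, which also carries hydrogen on that aromatic carbon, shows the lower number in this assay, yet its other end differs from compound 2 as well, so the result cannot simply be carried over. The expected step of a 1.8-fold lower number from compound 2 to compound 3 (0.26 log units; within the scatter) is modest, toward a lower number, and may stay within the scatter. Compound 3 is therefore estimated at 5 nM, within a range from 1.5 nM to 20 nM.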

Compound 3, inhibition constant: 1.2 nM
Beside the measured number, compound 3's estimate is 4.2-fold (0.62 log units) above it; the whole stated range lies above it.
By their numbers in this assay, from the lowest: compounds 1 and 3 (each within the scatter of the next); then compound 2.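

In this assay, hydrogen in place of (piperidin-1-yl)methyl on the aromatic carbon gives a 7.5-fold lower number from compound 2 to compound 3 (0.88 log units; beyond the scatter), so this position does alter the number, and the whole arm can go without any loss in binding. With hydrogen on that carbon, 6-(methoxycarbonyl)pyridin-2-yl in place of methylsulfonyl gives no change at the digits printed from compound 1 to compound 3 (within the scatter), which means that, of the two places where compounds 1 and 2 differ, only the arm has a step beyond the scatter. Nothing at hand explains either step.

Going by these compounds alone, whether the other end stays as silent with the (piperidin-1-yl)methyl arm in place remains open, since that pairing has only the one compound behind it. Also open, from the compounds shown here alone, is how a shorter amine such as aminomethyl, or a carboxylic acid on the same aromatic carbon, would fall relative to hydrogen and the full arm.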